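The compounds below may be only part of what the source reports. "The series", "measured", "known", "first", "only" and "open" are said of these compounds alone.

Compound 1 `COc1cc2ncnc(Nc3ccc(Br)cc3F)c2cc1OCCCN1CCNCCNCCNCC1`: 1840 nM
Compound 2 `COc1cc2ncnc(Nc3ccc(Cl)c(C(F)(F)F)c3)c2cc1OCCCN1CCNCCNCCNCC1`: 1710 nM

In a functional assay on A-431 cells (Homo sapiens) for antiproliferative activity, read by MTT assay, with a stated time of 72 h (a higher number here means a weaker inhibitor, a lower number a stronger inhibitor), compound 1 gives 1840 nM and compound 2 gives 1710 nM. Compound 2 stands alongside compound 1, the two numbers lying within the scatter of each other, so neither can be called the stronger. Compound 3 `COc1cc2ncnc(Nc3ccc(Cl)cc3Cl)c2cc1OCCCN1CCNCCNCCNCC1` has not been measured yet. It differs from compound 2 in one place: 2,4-dichlorophenyl in place of 4-chloro-3-(trifluoromethyl)phenyl on a nitrogen on an aromatic ring. For the measured compounds named here, only one measured step bears on a change at this position: a 1.1-fold lower number from compound 1 to compound 2 (0.03 log units; within the scatter), where 4-chloro-3-(trifluoromethyl)phenyl replaced 4-bromo-2-fluorophenyl on a nitrogen on an aromatic ring and the number stayed within the scatter. On that basis, a further exchange of the group on a nitrogen on an aromatic ring is expected to shift the number by no more than the scatter. For compound 3 the expected step is a 1.0-fold higher number from compound 2 to compound 3 (0.01 log units; within the scatter). Compound 3 is therefore estimated at 1750 nM, with a range from 900 nM to 3500 nM.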

Compound 3, half-maximal inhibitory concentration: 4390 nM
For compound 3 the middle estimate is 2.5-fold (0.40 log units) below the measured one; the whole stated range lies below it.
By their numbers in this assay, from the lowest: compounds 2 and 1 (each within the scatter of the next); then compound 3.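

The group on this nitrogen cannot be exchanged freely: in this assay the move to 2,4-dichlorophenyl gives a 2.6-fold higher number from compound 2 to compound 3 (0.41 log units; beyond the scatter) and, measured from the other parent, a 2.4-fold higher number from compound 1 to compound 3 (0.38 log units; beyond the scatter). Compounds 1 and 2 carry different substituted phenyl groups yet stay within the scatter of each other, so that earlier match did not extend to every halogen-bearing phenyl group, and compound 3 is the one that goes against it, though only modestly. Nothing measured here offers a reason for this shift.

The compounds shown leave open whether a plain 4-chlorophenyl or a 2,4-difluorophenyl would sit with compound 3 or with compounds 1 and 2. They also leave open how the number would respond to a morpholine in place of the large nitrogen-containing ring that all three share.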